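Triazole series: aryl in place of the nonyl chain

This account rests on a few compounds, and the source may have more. Where it says the series, first, only, none or still open, it means among the compounds named here.

Compound 1 `CCCCCCOc1ccc(-n2cnnc2C)cc1` gives 22.8 mg/kg in a functional assay on the whole organism (strain C57B/6) with Mus musculus as the target, in the maximal electroshock model; on this read-out higher numbers stand for an effect only at larger amounts of compound and lower numbers for an effect already at smaller amounts. Compound 2 `CCCCCCCc1nncn1-c1ccc(OCCCCCC)cc1` reaches only the limit of the assay, > 40 mg/kg. Compound 3 `CCCCCCCCCc1nncn1-c1ccc(OCCCCCC)cc1` likewise reaches only a limit, > 40 mg/kg. The two steps that lengthen the chain on the core read as an at least 1.7-fold higher number from compound 1 to compound 2 (0.24 log units; that floor lies within the scatter) and an at least 1.7-fold higher number from compound 1 to compound 3 (0.24 log units; that floor lies within the scatter), and the further lengthening reads as a step that the two limits leave unreadable from compound 2 to compound 3. Compound 3 thus stands on a limit rather than a number, the situation described by the limit of > 40 mg/kg in this assay, at which 2 of the 3 values shown sit.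

Compound 4 `CCCCCCOc1ccc(-n2cnnc2-c2cccc(F)c2)cc1` differs from compound 3 by 3-fluorophenyl in place of nonyl on an aromatic carbon. Among the compounds with values here, the only steps that touch this position are those from compound 1, where a hexyl or an octyl entering in place of hydrogen pushed the value past the limit; no measured step covers an aromatic group entering there. Removing the nonyl points back toward the number of compound 1, while the entering 3-fluorophenyl is a change of a kind not yet seen, so the expected step is set as an at least 1.3-fold lower number from compound 3 to compound 4 (0.12 log units; that floor lies within the scatter) in this assay , with wide uncertainty. For compound 4 the expected value is 30 mg/kg, in the range 12 mg/kg to 60 mg/kg.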

Compound 4, dose for half-maximal effect: 27.4 mg/kg
Beside the measured number, compound 4's estimate is 1.1-fold (0.04 log units) above it, within the range that was stated.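

Compound 4 returns a number in this assay, so 3-fluorophenyl, with its one six-membered aromatic ring, is the first group shown other than methyl on this aromatic carbon between two ring nitrogen atoms that does not end at a limit. Against the small group the result reads as a 1.2-fold higher number from compound 1 to compound 4 (0.08 log units; within the scatter), so compound 1 and compound 4 cannot be told apart on this read-out, and the entering ring carries no visible cost relative to methyl. Against the two chains the result reads as an at least 1.4-fold lower number from compound 2 to compound 4 (0.16 log units; that floor lies within the scatter) and an at least 1.4-fold lower number from compound 3 to compound 4 (0.16 log units; that floor lies within the scatter), and both of these are floors set by limits rather than measured sizes: the limit of > 40 mg/kg in this assay, at which 2 of the 4 values shown sit.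

Open, on these data alone, is whether an unsubstituted phenyl or a 4-fluorophenyl at this position would read like compound 4, which would show whether the fluorine or its place on the ring counts at all. Equally open, as far as these compounds go, is whether a chain shorter than heptyl, such as ethyl, or an amine such as dimethylaminomethyl would stay on a number here or run to the limit.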